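The source may report more compounds than this note shows. Statements on the series, on what has been measured and on what is new or still open speak of the compounds shown alone.

Compound 1 `CCCCN(CC)c1cc(C)nc2c(-c3ccc(Cl)cc3Cl)c(C)nn12` is measured in an assay on CHO cells for displacement of a labelled ligand from corticotropin-releasing factor receptor 1 (Homo sapiens) (on this read-out lower numbers stand for stronger inhibition and higher numbers for weaker inhibition), and gives 5 nM, the lower of the two numbers recorded. Compound 2 `CCCCN(CC)c1cc(C)nc2c(-c3ccc(Cl)cc3Cl)cnn12` gives 40 nM in this assay, and the step of an 8.0-fold higher number from compound 1 to compound 2 (0.90 log units; beyond the scatter) comes from hydrogen in place of methyl on an aromatic carbon. Compound 3 `CCCC1CCCCN1c1cc(C)nc2c(-c3ccc(Cl)cc3Cl)c(C)nn12` differs from compound 1 in another way: 2-propylpiperidin-1-yl in place of butyl(ethyl)amino on an aromatic carbon. Among the measured compounds shown here, no measured step touches this amine position, so the expectation rests on compound 1 alone and is taken as a 1.4-fold higher number from compound 1 to compound 3 (0.15 log units; within the scatter), a change not expected to exceed the scatter. Compound 3 is therefore estimated at 7 nM, within a range from 2 nM to 30 nM.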

Compound 3, inhibition constant: 6.4 nM
Beside the measured number, compound 3's estimate is 1.1-fold (0.04 log units) above it; measured number inside the range.
By their numbers in this assay, from the lowest: compounds 1 and 3 (each within the scatter of the next); then compound 2.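

Putting 2-propylpiperidin-1-yl in place of butyl(ethyl)amino gives a 1.3-fold higher number from compound 1 to compound 3 (0.11 log units; within the scatter) in this assay, so the two numbers cannot be told apart. Among the compounds shown here, this is the first reading at the amine position, and it shows that an open chain amine and a six-membered non-aromatic ring carrying a propyl group can both sit there with low nanomolar numbers. No measurement at hand accounts for this result.

Still open, as far as these compounds go, is how a smaller ring such as pyrrolidin-1-yl, or a ring with an added oxygen such as morpholin-4-yl, would read here. Also open, from the compounds shown here alone, is whether hydrogen in place of methyl would cost as much alongside 2-propylpiperidin-1-yl.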